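Shortening the Basic Side Chain on a Cytotoxic Core

This account rests on a few compounds, and the source may have more. Where it says the series, first, only, none or still open, it means among the compounds named here.

Compound 1, `CN1CCN(CCCCn2c3c(c4ccccc42)C(=O)c2c[n+]([O-])c4ccccc4c2C3=O)CC1`: 110 nM
Compound 2, `CC1(C)OC[C@H](Cn2cc(Cn3c4c(c5ccccc53)C(=O)c3c[n+]([O-])c5ccccc5c3C4=O)nn2)O1`: 530 nM

In a functional assay on MDA-MB-231 cells (Homo sapiens) for cytotoxicity, read by MTT assay, with a stated time of 72 h (a lower number here means a stronger inhibitor, a higher number a weaker inhibitor), compound 1 gives 110 nM, the lowest of the two numbers; compound 2 gives 530 nM, a gap beyond the usual scatter. Compound 3, `O=C1c2c[n+]([O-])c3ccccc3c2C(=O)c2c1c1ccccc1n2CCN1CCCCC1`, keeps the shared core and changes only the side chain: piperidin-1-yl in place of 2-(4-methylpiperazin-1-yl)ethyl on a saturated chain carbon, two bonds along the chain from an aromatic nitrogen. For the measured compounds named here, no measured pair shows this kind of change, so the step of a 1.5-fold higher number from compound 1 to compound 3 (0.16 log units; within the scatter) is expected to be small, at most near the edge of the scatter, with the direction uncertain. Compound 3 is therefore expected to give about 160 nM, most likely between 50 nM and 500 nM.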

Compound 3, half-maximal inhibitory concentration: 1050 nM
Estimate against measurement, compound 3: 6.6-fold (0.82 log units) below, outside the stated range (above it).
By their numbers in this assay, from the lowest: compound 1; then compounds 2 and 3 (each within the scatter of the next).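

In this assay, going from 4-(4-methylpiperazin-1-yl)butyl to 2-(piperidin-1-yl)ethyl gives a 9.5-fold higher number from compound 1 to compound 3 (0.98 log units; beyond the scatter), so this side chain is not a place where changes pass unnoticed. The step alters the ring and the chain length together, and it cannot show which of the two matters. Nothing available here explains the size of the step. The compounds shown leave that question open: a 4-(piperidin-1-yl)butyl chain, or a 2-(4-methylpiperazin-1-yl)ethyl chain, would pull the two changes apart.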